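The source may hold more compounds than are shown below. What is called first, only, known or untested is meant among the compounds shown, and "the series" means these compounds.

Series notes, antiproliferative read-out in a functional assay on K562 cells (Homo sapiens) for antiproliferative activity, with a stated time of 72 h; on this read-out higher numbers stand for weaker inhibition and lower numbers for stronger inhibition:

Compound 1 `OC[C@H]1O[C@@H](n2cnc3c(NCc4ccccc4F)ncnc32)[C@H](O)[C@@H]1O` gives 33200 nM.
Compound 2 `OC[C@H]1O[C@@H](n2cnc3c(NCc4ccccc4Cl)ncnc32)[C@H](O)[C@@H]1O` gives 64000 nM.
Compound 3 `COc1ccccc1CNc1ncnc2c1ncn2[C@@H]1O[C@H](CO)[C@@H](O)[C@H]1O` gives 89000 nM.

Compound 2 sits between the other two on these numbers. Its gap to compound 3 is a 1.4-fold higher number from compound 2 to compound 3 (0.14 log units; within the scatter) and the other gap is a 1.9-fold higher number from compound 1 to compound 2 (0.29 log units; within the scatter), both inside the scatter, so compound 2 is not separated from either neighbour. Among the measured compounds shown here, the only step that clears the scatter is a 2.7-fold higher number from compound 1 to compound 3 (0.43 log units; beyond the scatter), and it is modest.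

Compound 4 `OC[C@H]1O[C@@H](n2cnc3c(NCc4ccc(F)cc4F)ncnc32)[C@H](O)[C@@H]1O` is the next member, not yet measured. Against compound 2 the change is 2,4-difluorophenyl in place of 2-chlorophenyl on a saturated chain carbon bound to a nitrogen on an aromatic ring. Of the measured steps, only a 1.9-fold higher number from compound 1 to compound 2 (0.29 log units; within the scatter) bears on it, since the chloro-to-fluoro part of the change is that step run backwards, and it lies within the scatter. For the measured compounds named here, the second fluoro has no counterpart among the measured compounds, so nothing is known about it here. The expectation is therefore a number close to that of compound 1, a step of a 2.0-fold lower number from compound 2 to compound 4 (0.30 log units; within the scatter), which is not expected to pass beyond the scatter.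

In this assay compound 4 is expected to give about 32000 nM, estimated within 12000 nM to 80000 nM.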

Compound 4, half-maximal inhibitory concentration: 9600 nM
Compound 4: the middle estimate sits 3.3-fold (0.52 log units) above what was measured; measured number outside the range, below it.
By their numbers in this assay, from the lowest: compound 4; then compounds 1, 2 and 3 (each within the scatter of the next, the first and the last beyond it).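

In this assay, fluoro in place of hydrogen on an aromatic carbon gives a 3.5-fold lower number from compound 1 to compound 4 (0.54 log units; beyond the scatter), so the ring of compound 1 can take a further substituent and still give a lower number, something the single-substituent compounds could not show. The exchange of 2-chlorophenyl for 2,4-difluorophenyl on a saturated chain carbon bound to a nitrogen on an aromatic ring gives a 6.7-fold lower number from compound 2 to compound 4 (0.82 log units; beyond the scatter), and the exchange from the 2-methoxyphenyl compound gives a 9.3-fold lower number from compound 3 to compound 4 (0.97 log units; beyond the scatter), which makes compound 4 the strongest of the four on this read-out. Most of the step from compound 2 therefore goes with the added fluoro and not with the chloro-to-fluoro exchange, though no measurement here accounts for that gain.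

Open, going by these compounds, is whether a chloro, a trifluoromethyl group, an amine or a carboxylic acid in place of the added fluoro would keep the number as low. Also open, on these data alone, is whether the added fluoro would give a similar step on a ring without the first fluoro, or with the chloro of compound 2 or the methoxy of compound 3 in its place.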